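Epimer of a Furan Analogue: Expected Lipophilicity Unchanged

This account rests on a few compounds, and the source may have more. Where it says the series, first, only, none or still open, it means among the compounds named here.

Compound 1 `CC1(C)CC(NC(=O)C(/C=C/[C@H](NC(=O)OC(C)(C)C)c2ccc(F)cc2)(Cc2ccc(F)cc2)Cc2ccc(F)cc2)CC(C)(C)N1` gives 7.9.
Compound 2 `CC1(C)CC(NC(=O)C(/C=C/[C@@H](NC(=O)OC(C)(C)C)c2ccoc2)(Cc2ccc(F)cc2)Cc2ccc(F)cc2)CC(C)(C)N1` gives 6.

Both numbers come from a physicochemical assay for lipophilicity; on this read-out higher numbers stand for higher lipophilicity and lower numbers for lower lipophilicity. Compound 2 stands lowest of the two; its nearest neighbour is compound 1, whose value lies higher by a margin beyond the scatter. Within the data shown here, no step between two measured compounds that differ in a single place is available, so no measured pair can guide the next move directly. Compound 3 `CC1(C)CC(NC(=O)C(/C=C/[C@H](NC(=O)OC(C)(C)C)c2ccoc2)(Cc2ccc(F)cc2)Cc2ccc(F)cc2)CC(C)(C)N1` is the compound yet to be measured. Its relation to compound 2 is this: the two compounds have the same atoms and bonds and differ only in configuration as drawn: 1 of 2 stereo elements differ; a stereocentre at a saturated chain carbon is drawn R in compound 2 and S in compound 3. The measured pair offers no comparison of two configurations of the same atoms and bonds. In this assay the step from compound 2 to compound 3 is expected to be no change at the digits printed from compound 2 to compound 3 (within the scatter), that is, none beyond the scatter. Compound 3 is therefore estimated at 6, with a range from 5.7 to 6.3.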

Compound 3, partition coefficient: 6
Compound 3: middle estimate and measured number agree at the digits printed; the measured number falls inside the stated range.
By their numbers in this assay, from the lowest: compounds 2 and 3 (each within the scatter of the next); then compound 1.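

In this assay, among these compounds, the saturated chain carbon bearing furan-3-yl now gives a first comparison of two configurations of the same atoms and bonds, and the outcome is no change at the digits printed from compound 2 to compound 3 (within the scatter). This step reads configuration at that carbon alone: the fact that compounds 2 and 3 differ only in the configuration as drawn. The exchange of 4-fluorophenyl for furan-3-yl on that carbon can also now be read as a change in one place, and it gives a number 1.90 log units lower from compound 1 to compound 3 (beyond the scatter).

The only pair of configurations shown carries furan-3-yl, so it remains open whether the same absence of a step would hold with 4-fluorophenyl on that carbon. Going by these compounds, it also remains open how this assay would read with an amine or a carboxylic acid on that carbon in place of either group.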